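The compounds below may be only part of what the source reports. "The series", "measured", "known", "first", "only" and "open" are said of these compounds alone.

Measured in a functional assay on A549 cells (Homo sapiens) for cytotoxicity, read by MTT assay, with a stated time of 72 h; on this read-out higher numbers stand for weaker inhibition and lower numbers for stronger inhibition:
- compound 1 `CN(C)Cc1ccc2nc(NC(=O)N/N=C/c3cn(Cc4ccccc4Cl)c4ccccc34)sc2c1`: 1080 nM
- compound 2 `CC1CCN(Cc2ccc3nc(NC(=O)N/N=C/c4c[nH]c5ccccc45)sc3c2)CC1`: 3580 nM

Compound 2 has the higher of the two numbers, and its gap to compound 1 lies beyond the scatter. Compound 3 `CC1CCN(Cc2ccc3nc(NC(=O)N/N=C/c4cn(Cc5ccccc5Cl)c5ccccc45)sc3c2)CC1` is compound 2 with 2-chlorobenzyl in place of hydrogen on an aromatic nitrogen. Going by the values given here, no measured pair isolates this change, so the expectation rests on one indirect comparison. Compound 1 carries the same 2-chlorobenzyl group and gives 1080 nM, but it also differs from compound 2 elsewhere in the structure. A lower number, beyond the scatter, is therefore expected in this assay, with the size of the change uncertain. The expected change is a 4.5-fold lower number from compound 2 to compound 3 (0.65 log units; beyond the scatter). For compound 3 the estimated value is 800 nM, with an expected range of 250 nM to 2500 nM.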

Compound 3, half-maximal inhibitory concentration: 3330 nM
For compound 3 the middle estimate is 4.2-fold (0.62 log units) below the measured one; the whole stated range lies below it.
By their numbers in this assay, from the lowest: compound 1; then compounds 3 and 2 (each within the scatter of the next).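

In this assay, 2-chlorobenzyl in place of hydrogen on the aromatic nitrogen gives a 1.1-fold lower number from compound 2 to compound 3 (0.03 log units; within the scatter) with 4-methylpiperidin-1-yl present, so this substitution on that nitrogen does not separate the two compounds. Going by these compounds alone, with 2-chlorobenzyl held, 4-methylpiperidin-1-yl in place of dimethylamino on the saturated chain carbon gives a 3.1-fold higher number from compound 1 to compound 3 (0.49 log units; beyond the scatter) and is the only single-place change here that moves the number beyond the scatter. No measured data bear on the cause of either result.

Open, as far as these compounds go, is whether the 2-chlorobenzyl step stays as small with dimethylamino on the chain carbon. Also open, from the compounds shown here alone, is how a morpholine at that carbon, or a plain benzyl or methyl on the aromatic nitrogen, would read.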